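A benzyloxy group gives way in compound 4

This account rests on a few compounds, and the source may have more. Where it says the series, first, only, none or still open, it means among the compounds named here.

Values in a functional assay on MOLT-4 cells (Homo sapiens); a lower number here means a stronger inhibitor, a higher number a weaker inhibitor:
Compound 1 `COc1cc(NC(C)CCCNC(=O)NCCO)c2ncccc2c1`: > 100000 nM (a limit)
Compound 2 `COc1cc(NC(C)CCCNC(=O)NCCCO)c2ncccc2c1`: > 100000 nM (a limit)
Compound 3 `COc1cc(NC(C)CCCNC(=O)NOCc2ccccc2)c2ncccc2c1`: 12000 nM
Compound 4 `COc1cc(NC(C)CCCNC(=O)N(CCO)CCO)c2ncccc2c1`: not yet measured

Compound 3 alone has a readable number in this assay, at 12000 nM. Compound 1 and compound 2 stand at the limit of > 100000 nM in this assay, at which 2 of the 3 values shown sit.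

The next change is bis(2-hydroxyethyl)amino in place of (benzyloxy)amino on a carbonyl carbon. Within the data shown here, two measured steps bear on it. Benzyloxy in place of 2-hydroxyethyl on an amide-type nitrogen gave an at least 8.3-fold lower number from compound 1 to compound 3 (0.92 log units; beyond the scatter), and benzyloxy in place of 3-hydroxypropyl gave an at least 8.3-fold lower number from compound 2 to compound 3 (0.92 log units; beyond the scatter). Both are beyond the scatter, and each gives only a minimum size. Compound 4 has no benzyloxy group and carries 2-hydroxyethyl groups instead, so a step of at least modest size is expected in the opposite direction, towards a higher number in this assay. The reading may well turn out to be a limit. The estimated step is an 8.3-fold higher number from compound 3 to compound 4 (0.92 log units; beyond the scatter). For compound 4 the expected value is 100000 nM, with an estimated range from 30000 nM to 300000 nM.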

Compound 4, half-maximal inhibitory concentration: > 100000 nM
Compound 4 ended at the assay's limit (the forecaster's own chance of this, stated with the estimate: 70%); the middle value lies on the limit itself.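

In this assay, among these compounds, the one readable step at this position is an at least 8.3-fold higher number from compound 3 to compound 4 (0.92 log units; beyond the scatter), so the change to bis(2-hydroxyethyl)amino on the carbonyl carbon takes the series from its only numbered compound back to the limit. The earlier compounds shown here had only a single hydroxyalkyl chain on the amide-type nitrogen, and compound 4 shows that a second 2-hydroxyethyl group on that nitrogen does not bring back a readable number. The steps from compound 1 and from compound 2 to compound 4 cannot be read, since all three compounds give only a limit and not a number: the limit of > 100000 nM in this assay, at which 3 of the 4 values shown sit.

As far as these compounds go, whether the value of compound 3 depends on the six-membered aromatic ring or on the oxygen attached to the amide-type nitrogen remains open. A benzyl group, which lacks that oxygen, and a methoxy group, which lacks the ring, would separate the two.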